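The compounds below may be only part of what the source reports. "The series", "measured", "known", "first", "only" and "open" are said of these compounds alone.

Measured compounds in the series:
- compound 1, `Cc1cn([C@H]2C[C@H](O)[C@@H](OP(=O)(O)O)O2)c(=O)[nH]c1=O`: 138000000 nM
- compound 2, `CCCc1cn([C@H]2C[C@H](O)[C@@H](OP(=O)(O)O)O2)c(=O)[nH]c1=O`: 8130000 nM
- compound 3, `O=Cc1cn([C@H]2C[C@H](O)[C@@H](OP(=O)(O)O)O2)c(=O)[nH]c1=O`: 16200000 nM

All three share one core and differ only in the group on the aromatic carbon. In an assay on L1210 cells for inhibition of Thymidylate synthase (Mus musculus) (a higher number here means a weaker inhibitor, a lower number a stronger inhibitor), compound 2 gives the lowest of the three numbers; the nearest is compound 3, separated by a 2.0-fold higher number from compound 2 to compound 3 (0.30 log units; within the scatter), which does not set the two apart, while the furthest is compound 1, separated by a 17-fold lower number from compound 1 to compound 2 (1.23 log units; beyond the scatter). Replacing methyl by formyl on the aromatic carbon also moves the number down, as an 8.5-fold lower number from compound 1 to compound 3 (0.93 log units; beyond the scatter) shows.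

Compound 4, `O=c1[nH]c(=O)n([C@H]2C[C@H](O)[C@@H](OP(=O)(O)O)O2)cc1[N+](=O)[O-]`, has not yet been measured in this assay. It differs from compound 2 by nitro in place of propyl on an aromatic carbon. For the measured compounds named here, no step with a nitro group has been measured, so the only bearing comes from the two changes at the same carbon: both the step to propyl and the step to formyl lowered the number against compound 1, and compound 2 and compound 3 sit within the scatter of each other. The expectation is therefore that compound 4 lands near compound 2, with a step of a 4.1-fold lower number from compound 2 to compound 4 (0.61 log units; beyond the scatter), possibly somewhat lower but with little firm support for a large move in either direction. Compound 4 is estimated at 2000000 nM, within a range of 200000 nM to 10000000 nM.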

Compound 4, inhibition constant: 2570000 nM
Beside the measured number, compound 4's estimate is 1.3-fold (0.11 log units) below it; the range from low to high includes it.
By their numbers in this assay, from the lowest: compound 4; then compounds 2 and 3 (each within the scatter of the next); then compound 1.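

Nitro at this aromatic carbon separates from both groups that could not be told apart before, propyl (a 3.2-fold lower number from compound 2 to compound 4 (0.50 log units; beyond the scatter)) and formyl (a 6.3-fold lower number from compound 3 to compound 4 (0.80 log units; beyond the scatter)), so in this assay this position still distinguishes among the groups that improve on methyl. Against methyl, the change gives the largest step seen at this carbon (a 54-fold lower number from compound 1 to compound 4 (1.73 log units; beyond the scatter)), and compound 4 is the strongest inhibitor of the four, with its steps to all the others beyond the scatter. Propyl and nitro have the same count of heavy atoms, yet compound 2 and compound 4 are set apart, so that count alone does not order the series; nothing measured here accounts for the order.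

Open, as far as these compounds go, is whether an amine, a carboxylic acid, a nitrile or a chain longer than propyl on the same carbon would continue this trend or reverse it. From the compounds shown here alone, with only methyl, propyl, formyl and nitro at this position, it also remains open whether a halogen such as fluorine or bromine would fall nearer to compound 4 or to compound 1.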